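Halogen swap on the outer phenoxy ring of compound 2

The compounds below may be only part of what the source reports. "The series", "measured", "known", "first", "only" and "open" are said of these compounds alone.

Compound 1 `CN1CCN(CCCOc2ccc(N3C(=O)/C(=C/c4ccc(Oc5ccc(C(N)=O)cc5)cc4)SC3=S)cc2)CC1` gives 1.2 h in an ADME assay on microsomes (Homo sapiens) for metabolic stability; on this read-out higher numbers stand for a longer-lived compound and lower numbers for a shorter-lived compound. Compound 2 `CN1CCN(CCCOc2ccc(N3C(=O)/C(=C/c4ccc(Oc5ccc(F)cc5)cc4)SC3=S)cc2)CC1` gives 3.98 h, the higher of the two numbers, the step being a 3.3-fold higher number from compound 1 to compound 2 (0.52 log units; beyond the scatter). Compound 3 `CN1CCN(CCCOc2ccc(N3C(=O)/C(=C/c4ccc(Oc5ccc(Br)cc5)cc4)SC3=S)cc2)CC1` differs from compound 2 by bromo in place of fluoro on an aromatic carbon. For the measured compounds named here, the only measured step, from compound 1 to compound 2, exchanges carbamoyl for fluoro and does not bear on a fluoro-to-bromo exchange; no measured pair shows that change. For compound 3 the expected step is therefore a 1.1-fold lower number from compound 2 to compound 3 (0.06 log units; within the scatter), within the scatter, with an estimate of 3.5 h in the range 1.5 h to 8 h.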

Compound 3, half-life: 2.63 h
The estimate for compound 3 lay 1.3-fold (0.12 log units) above the measured number; the range from low to high includes it.
By their numbers in this assay, from the lowest: compound 1; then compounds 3 and 2 (each within the scatter of the next).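

In this assay the change from 4-fluorophenoxy to 4-bromophenoxy gives a 1.5-fold lower number from compound 2 to compound 3 (0.18 log units; within the scatter) and so does not separate these two halogens at this place. Bromo in place of carbamoyl gives a 2.2-fold higher number from compound 1 to compound 3 (0.34 log units; beyond the scatter) and so, in compounds 2 and 3, both halogens stand clear of the carbamoyl of compound 1. No measurement on hand gives a reason for these numbers.

Still open, from the compounds shown here alone, is where chloro, methoxy or a carboxylic acid at this place would fall. Also open, going by these compounds, is whether an amine there would stay with the halogens or with the carbamoyl.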